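Swapping the aryl group on the acylhydrazone of compound 2

A few compounds are considered here, and "the series" means these few. Any claim that something is new, unique, unknown or untested is made for them only; others in the source may bear on it.

Measured compounds:
Compound 1 `N#Cc1ccc(/C=N/NC(=O)Nc2cc3c(Nc4ccc(F)c(Cl)c4)ncnc3cc2O[C@H]2CCOC2)cc1`: "not determined" (no result reported)
Compound 2 `COc1cc2ncnc(Nc3ccc(F)c(Cl)c3)c2cc1NC(=O)N/N=C/c1ccc(C#N)cc1`: "not determined" (no result reported)
Compound 3 `COc1cc2ncnc(Nc3ccc(F)c(Cl)c3)c2cc1NC(=O)N/N=C/c1cc(C(C)(C)C)c(O)c(C(C)(C)C)c1`: 28300 nM

In a functional assay on MCF7 cells (Homo sapiens) for cytotoxicity, read by MTT assay, with a stated time of 72 h (a lower number here means a stronger inhibitor, a higher number a weaker inhibitor), compound 3 gives 28300 nM, a weak result. Compound 2 stands without a number; its entry reports no result, as does that of compound 1. The change leading to compound 4 `CCN(CC)c1ccc(/C=N/NC(=O)Nc2cc3c(Nc4ccc(F)c(Cl)c4)ncnc3cc2OC)c(O)c1` is 4-(diethylamino)-2-hydroxyphenyl in place of 4-cyanophenyl on a carbon with a double bond to nitrogen. Among the compounds with values here, with no number for compound 2, no step can be given a direction, and the only anchor is the weak value of compound 3, which shares the core. Compound 4 is therefore expected to be weak as well, estimated at 20000 nM with a range from 5000 nM to 80000 nM.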

Compound 4, half-maximal inhibitory concentration: 27300 nM
Compound 4: the middle estimate sits 1.4-fold (0.14 log units) below what was measured; measured number inside the range.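

Compound 2 has no number to set against compound 4, so no step can be read between them. From the compounds shown here alone, whether 4-(diethylamino)-2-hydroxyphenyl in place of 4-cyanophenyl changes the result in this assay stays open. No supporting evidence bears on this result.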